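Vinyl for Iodo on Two Fused Five-Membered Cores

A few compounds are considered here, and "the series" means these few. Any claim that something is new, unique, unknown or untested is made for them only; others in the source may bear on it.

Compound 1 `C=Cc1nc2ccccc2n1C`: 2340 nM
Compound 2 `Cn1c(I)nc2ccccc21`: 1020 nM
Compound 3 `Ic1nc2ccccc2o1`: 11700 nM

In a functional assay on NCI-H522 cells (Homo sapiens) for cytotoxicity, with a stated time of 3 days (a lower number here means a stronger inhibitor, a higher number a weaker inhibitor), compound 3 stands highest of the three. The difference between the core of compound 3 and the core of compound 2 is not broken down here. Within the core of compound 2, the change vinyl in place of iodo on an aromatic carbon gave a 2.3-fold higher number from compound 2 to compound 1 (0.36 log units; beyond the scatter).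

Compound 4 `C=Cc1nc2ccccc2o1` carries the same kind of change, (vinyl in place of iodo on an aromatic carbon), but the place differs: in compound 3 the ring holds 1 nitrogen and 1 oxygen, and the carbon is next to the ring nitrogen and next to the ring oxygen, whereas in compound 2 it lies between two ring nitrogen atoms and next to the ring atom that bears a methyl group. Resting on the step of a 2.3-fold higher number from compound 2 to compound 1 (0.36 log units; beyond the scatter), compound 4 is expected to give 25000 nM, an estimated 2.1-fold higher number from compound 3 to compound 4 (0.33 log units; beyond the scatter), with a range from 8000 nM to 80000 nM.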

Compound 4, half-maximal inhibitory concentration: > 40000 nM
Compound 4 was reported as a limit (the forecaster's own chance of this, stated with the estimate: 20%); middle value at least 1.6-fold (0.20 log units) from the limit.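

On the core of compound 3, vinyl in place of iodo again raised the number in this assay, giving an at least 3.4-fold higher number from compound 3 to compound 4 (0.53 log units; beyond the scatter) and so matching the direction seen on the core of compound 2. For compound 4 the reading of > 40000 nM is a limit of the assay and not a number. The direction of the change therefore carries across these two cores, but whether its size does remains unshown: the same change on two cores in this assay, a 2.3-fold higher number (0.36 log units; beyond the scatter) from compound 2 to compound 1 and an at least 3.4-fold higher number (0.53 log units; beyond the scatter) from compound 3 to compound 4; the limit leaves it open whether they differ.

The compounds shown leave open how an amine or a carboxylic acid in place of iodo would read on either core. They also leave open whether the same direction would hold on any core beyond these two.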